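Ethoxy in place of chloro on the shared core

The source may report more compounds than this note shows. Statements on the series, on what has been measured and on what is new or still open speak of the compounds shown alone.

Measured so far in a functional assay on the whole organism (strain Sprague-Dawley) for inhibition, with Rattus norvegicus as the target; on this read-out lower numbers stand for an effect already at smaller amounts and higher numbers for an effect only at larger amounts of compound:
compound 1 `O=C(O)c1cnc2c(C(F)(F)F)cccc2c1` gives 50 mg/kg.
compound 2 `Cc1cccc2cc(C(=O)O)cnc12` gives > 50 mg/kg, a limit of the assay and not a number.
compound 3 `O=C(O)c1cnc2c(Cl)cccc2c1` gives 25 mg/kg.

Of the two numbers, compound 3 sits at the lower end, but the nearest value, that of compound 1, is not separated from it: a 2.0-fold lower number from compound 1 to compound 3 (0.30 log units; within the scatter). The other step, an at least 2.0-fold lower number from compound 2 to compound 3 (0.30 log units; that floor lies within the scatter), is bounded only by the limit of > 50 mg/kg in this assay, at which 1 of the 3 values shown sits. Compound 4 `CCOc1cccc2cc(C(=O)O)cnc12` differs from compound 3 by ethoxy in place of chloro on an aromatic carbon. Both measured steps exchange a single group on that same aromatic carbon, one within the scatter and one open at the floor; no ether has been measured. A shift in this assay of no more than the scatter is therefore expected, in either direction. Compound 4 is estimated at 35 mg/kg, range 12 mg/kg to 100 mg/kg, meaning an expected step of a 1.4-fold higher number from compound 3 to compound 4 (0.15 log units; within the scatter).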

Compound 4, minimum effective dose: > 25 mg/kg
Compound 4 gave a limit, no number; the forecaster's own chance of this, stated with the estimate: 35%; the middle value lies beyond the limit too.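

In this assay compound 4 gives a limit and not a number: the limit of > 25 mg/kg in this assay, at which 1 of the 4 values shown sits. The exchange of chloro for ethoxy gives a number no lower from compound 3 to compound 4 (the limit leaves the size open), so this ether on the aromatic carbon shows no gain over chloro, although a value matching that of compound 3 is not excluded. The steps to compound 4 from compound 1 and from compound 2 cannot be read.

On these data alone, how far ethoxy moves the number stays open. Also open, as far as these compounds go, is what a methoxy, a fluoro or an amine on the same aromatic carbon would give.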